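Swapping an aryl urea for an acetylpiperidine urea

The source may report more compounds than this note shows. Statements on the series, on what has been measured and on what is new or still open speak of the compounds shown alone.

Of the compounds shown here, three sharing one core have been measured in a functional assay on Shh Light II cells (Mus musculus) for inhibition, read by a luciferase reporter; on this read-out lower numbers stand for stronger inhibition and higher numbers for weaker inhibition. Compound 2 `Cc1ccccc1NC(=O)N1CCC(c2nc(-c3ccc4ccccc4n3)no2)CC1` gives 440 nM, the lowest number of the three and therefore the strongest inhibitor among them. Compound 1 `C[C@@H]1C[C@H](c2nc(-c3ccc4ccccc4n3)no2)CCN1C(=O)Nc1ccccc1Cl` gives 2400 nM, and compound 3 `COc1ccccc1NC(=O)N1CCC(c2noc(-c3ccc4ccccc4n3)n2)CC1` gives 2400 nM, both well beyond the usual scatter from compound 2.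

Compound 4 `CC(=O)N1CCC(NC(=O)N2CCC(c3nc(-c4ccc5ccccc5n4)no3)CC2)CC1` differs from compound 2 in one place: 1-acetylpiperidin-4-yl in place of 2-methylphenyl on an amide-type nitrogen. An aromatic ring of carbon only is replaced by a non-aromatic ring carrying an acetyl group. Within the data shown here, no measured pair shows this exact change, so the step is expected to be a loss of inhibition of about a 6.8-fold higher number from compound 2 to compound 4 (0.83 log units; beyond the scatter). Compound 4 is expected to give roughly 3000 nM, within a range from 600 nM to 15000 nM.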

Compound 4, half-maximal inhibitory concentration: 500 nM
For compound 4 the middle estimate is 6.0-fold (0.78 log units) above the measured one, outside the stated range (below it).
By their numbers in this assay, from the lowest: compounds 2 and 4 (each within the scatter of the next); then compounds 1 and 3 (each within the scatter of the next).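

In this assay the swap of 2-methylphenyl for 1-acetylpiperidin-4-yl on the amide-type nitrogen gives a 1.1-fold higher number from compound 2 to compound 4 (0.06 log units; within the scatter) and leaves the two compounds level. For this pair, then, an aromatic ring of carbon only is not needed at this position to keep inhibition, and a non-aromatic ring carrying an acetyl group serves equally well. Nothing at hand explains why the two groups match.

Still open, from the compounds shown here alone, is whether the acetyl group itself matters. A plain cyclohexyl ring, or a piperidine carrying a free amine or a carboxylic acid, would test how much this position accepts.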